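Phenoxy in place of the ester-bearing aryl on the shared core

The source may hold more compounds than are shown below. What is called first, only, known or untested is meant among the compounds shown, and "the series" means these compounds.

Compound 1 `COC(=O)c1cccc(-c2ccc([C@H]3S[C@@H](C)C(=O)Nc4c3c(C)nn4-c3ccccc3C)cc2)c1` is reported in an assay on isolated protein for agonist activity at Bile acid receptor (Homo sapiens), read by AlphaScreen, with a stated time of 30 min (a higher number here means that more compound is needed for the effect, a lower number that less compound is needed), as "not active" (no number reported), so no number places it among the measured analogues. For the measured compounds named here, compound 2 `CCc1ccccc1-n1nc(C)c2c1NC(=O)[C@H](C)S[C@@H]2c1ccc(Oc2ccccc2)cc1` gives 1100 nM and compound 3 `Cc1ccc(-n2nc(C)c3c2NC(=O)[C@H](C)S[C@@H]3c2ccc(Oc3ccccc3)cc2)cc1` gives 3400 nM; the single measured step, a 3.1-fold higher number from compound 2 to compound 3 (0.49 log units; beyond the scatter), concerns the group on the aromatic nitrogen and does not bear directly on the change considered here. Compound 4 `COc1ccccc1Oc1ccc([C@H]2S[C@@H](C)C(=O)Nc3c2c(C)nn3-c2ccccc2C)cc1` arises from compound 1 by 2-methoxyphenoxy in place of 3-(methoxycarbonyl)phenyl on an aromatic carbon. Going by the values given here, no measured step covers this change; the only guide is that compound 2, with a phenoxy at the same aromatic carbon, gives 1100 nM and compound 3 gives 3400 nM, while compound 4 keeps the 2-methylphenyl on nitrogen of compound 1. Compound 4 is therefore expected near those values, estimated at 2000 nM with a range of 500 nM to 8000 nM.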

Compound 4, half-maximal effective concentration: 1700 nM
The estimate for compound 4 lay 1.2-fold (0.07 log units) above the measured number, within the range that was stated.
By their numbers in this assay, from the lowest: compounds 2, 4 and 3 (each within the scatter of the next, the first and the last beyond it).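

For the compounds shown here, compound 1 carries no number in this assay and no step to compound 4 can be read. The compounds shown leave open how 2-methoxyphenoxy compares with plain phenoxy while 2-methylphenyl stays on nitrogen. No supporting evidence bears on this result.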